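From compound 2 to compound 3: one ring exchanged

The compounds below may be only part of what the source reports. "The series", "measured", "known", "first", "only" and "open" are said of these compounds alone.

Within the data shown here, in a physicochemical assay for lipophilicity (a lower number here means a more polar compound, a higher number a more lipophilic compound), compound 2 `Cn1nccc1-c1cc(C(F)(F)F)ccc1[C@H]1CCOc2cc(S(=O)(=O)Nc3nccs3)ccc21` reads 2.2 and sits lowest of the two numbers so far. Compound 1 `Cc1nc(-c2cc(C(F)(F)F)ccc2[C@H]2CCOc3cc(S(=O)(=O)Nc4ncc(F)cn4)ccc32)co1` reads 2.8 as the other measured value. The gap between these two numbers lies beyond the scatter. Among the measured compounds shown here, compound 3 `Cc1nc(-c2cc(C(F)(F)F)ccc2[C@H]2CCOc3cc(S(=O)(=O)Nc4nccs4)ccc32)co1` has 2-methyl-1,3-oxazol-4-yl in place of 1-methyl-1H-pyrazol-5-yl on an aromatic carbon and no measured pair shows this exchange alone. Compound 1 carries the same 2-methyl-1,3-oxazol-4-yl but also differs elsewhere, so its 2.8 is only a loose guide. A modest rise is expected, estimated as a number 0.40 log units higher from compound 2 to compound 3 (beyond the scatter) in this assay overall. For compound 3 the estimate is 2.6 with a range of 2.2 to 3 as expected bounds.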

Compound 3, distribution coefficient: 2.9
Estimate against measurement, compound 3: 0.30 log units below; low and high end bracket the measured number.
By their numbers in this assay, from the lowest: compound 2; then compounds 1 and 3 (each within the scatter of the next).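

In this assay the exchange of 1-methyl-1H-pyrazol-5-yl for 2-methyl-1,3-oxazol-4-yl on the aromatic carbon can now be read alone, and it gives a number 0.70 log units higher from compound 2 to compound 3 (beyond the scatter) even though both rings have the same heavy-atom count. Placing 1,3-thiazol-2-yl instead of 5-fluoropyrimidin-2-yl on the sulfonamide nitrogen gives a number 0.10 log units higher from compound 1 to compound 3 (within the scatter) and so leaves that pair without a readable difference. Still open, from the compounds shown here alone, is whether the rise holds with other groups on the sulfonamide nitrogen, and how a ring carrying an amine or a carboxylic acid would read at this position. Nothing available explains why the two rings differ.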